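Aryl swap on the triazole: dichloro for dimethyl

This account rests on a few compounds, and the source may have more. Where it says the series, first, only, none or still open, it means among the compounds named here.

Compound 3 `COc1cc2c(Oc3ccc(NC(=O)c4cn(-c5c(C)cccc5C)nn4)cc3F)ccnc2cc1OCCCN1CCC(C)CC1` sits at the weaker end of what has been measured: in a functional assay on MKN-45 cells (Homo sapiens) for cytotoxicity, read by MTT assay, with a stated time of 72 h (a lower number here means a stronger inhibitor, a higher number a weaker inhibitor), compound 3 gives 4310 nM, the highest of the two numbers in hand. Going by the values given here, its nearest neighbour, compound 2 `COc1cc2c(Oc3ccc(NC(=O)c4cn(-c5ccccc5)nn4)cc3F)ccnc2cc1OCCCN1CCC(C)CC1`, gives 90 nM in this assay, and the one recorded step, a 48-fold higher number from compound 2 to compound 3 (1.68 log units; beyond the scatter), is the only measured movement. Compound 1 `COc1cc2c(Oc3ccc(NC(=O)c4cn(-c5c(Cl)cccc5Cl)nn4)cc3F)ccnc2cc1OCCCN1CCCCC1` carries the same dichlorophenyl as the new compound but on a plain piperidine, and in this assay compound 1 gives "not determined" (no result reported). Compound 4 `COc1cc2c(Oc3ccc(NC(=O)c4cn(-c5c(Cl)cccc5Cl)nn4)cc3F)ccnc2cc1OCCCN1CCC(C)CC1` differs from compound 3 as 2,6-dichlorophenyl in place of 2,6-dimethylphenyl on an aromatic nitrogen. Among the compounds with values here, no measured step touches this exact exchange; the only step available concerns two ortho methyls entering against a bare phenyl, and it does not say how chlorine compares with methyl in the same positions. With the substitution pattern kept, the expectation for compound 4 in this assay is a step of a 1.4-fold lower number from compound 3 to compound 4 (0.16 log units; within the scatter), which is to say no movement beyond the scatter, and an estimated value of 3000 nM with a range of 700 nM to 13000 nM.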

Compound 4, half-maximal inhibitory concentration: 120 nM
For compound 4 the middle estimate is 25-fold (1.40 log units) above the measured one, and the stated range ends above it.
By their numbers in this assay, from the lowest: compounds 2 and 4 (each within the scatter of the next); then compound 3.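

In this assay there is a 36-fold lower number from compound 3 to compound 4 (1.56 log units; beyond the scatter) when 2,6-dichlorophenyl replaces 2,6-dimethylphenyl, so the substitution pattern alone does not set the value at this position on the aromatic nitrogen. Against the bare phenyl there is a 1.3-fold higher number from compound 2 to compound 4 (0.12 log units; within the scatter) and, with that step within the scatter, compound 2 and compound 4 cannot be told apart, leaving 2,6-dimethylphenyl as the only one of the three groups that stands apart. Nothing in hand explains why chlorine and methyl part so widely here.

Going by these compounds, it remains open whether 2,6-difluorophenyl, 2,6-dimethoxyphenyl or a single chlorine on the phenyl would read like compound 4 or like compound 3. On these data alone, the effect of the methyl on the piperidine also stays open, as compound 1 offers no number for comparison.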